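Fluoro on the core of a furanylmethylamino quinazoline series

The source may report more compounds than this note shows. Statements on the series, on what has been measured and on what is new or still open speak of the compounds shown alone.

In a functional assay on DU-145 cells (Homo sapiens) for cytotoxicity, read by MTT assay, with a stated time of 2 days, tested at 10 uM (a lower number here means less inhibition, a higher number more inhibition at the concentration tested (going by the name of the read-out)), compound 2 `Clc1cccc(N2CCN(CCCCNc3nc(NCc4ccco4)c4ccccc4n3)CC2)c1Cl` gives 94.3%, the highest number among the three measured compounds. Compound 3 `Cc1cccc(N2CCN(CCCCNc3nc(NCc4ccco4)c4ccccc4n3)CC2)c1C` gives 93.6%, which is within the scatter of compound 2, while compound 1 `c1coc(CNc2nc(NCCCN3CCCC3)nc3ccccc23)c1` gives 40.1%, far lower. Among the compounds with values here, the only measured single change, a number 0.7 percentage points lower from compound 2 to compound 3 (within the scatter), touches the arylpiperazine end and left the result within the scatter. Within the data shown here, compound 4 `Fc1ccc2nc(NCCCCN3CCN(c4cccc(Cl)c4Cl)CC3)nc(NCc3ccco3)c2c1` differs from compound 2 by fluoro in place of hydrogen on an aromatic carbon; no measured step covers a change on this fused ring, so the one step that does exist offers only indirect support for a small effect. Compound 4 is therefore expected to show essentially no step beyond the scatter, a number 2.3 percentage points lower from compound 2 to compound 4 (within the scatter). The estimate for compound 4 is 92%, with a range from 80% to 98%.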

Compound 4, a percentage reported as inhibition, at one concentration (the size of the read-out at that concentration, not a potency): 95.5%
Estimate against measurement, compound 4: 3.5 percentage points below, within the range that was stated.
By their numbers in this assay, from the lowest: compound 1; then compounds 3, 2 and 4 (each within the scatter of the next).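

In this assay, within the data shown here, the step of a number 1.2 percentage points higher from compound 2 to compound 4 (within the scatter) gives the first reading for a change on the fused ring of the shared core, as the one earlier step touched only the arylpiperazine end. At this position, fluoro in place of hydrogen on an aromatic carbon leaves the read-out at one concentration unchanged within the scatter. Nothing available here gives a cause for this result.

On these data alone, whether a chloro, a methoxy or an amine at this position would leave the read-out equally unchanged stays open. So does the effect of fluoro on the other aromatic carbons of this ring.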